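The source may hold more compounds than are shown below. What is called first, only, known or untested is meant among the compounds shown, and "the series" means these compounds.

Measured compounds:
compound 1, `CN(C(=O)c1ccc(Cl)cc1)c1ccc2[nH]c(-c3n[nH]c4ccccc34)cc2n1`, with 3000 nM
compound 2, `CN(C(=O)c1ccccc1)c1ccc2[nH]c(-c3n[nH]c4cc(C#N)ccc34)cc2n1`, with 24000 nM

Both compounds were tested in a functional assay on HCT-116 cells (Homo sapiens) for antiproliferative activity, read by MTT assay, with a stated time of 72 h; on this read-out higher numbers stand for weaker inhibition and lower numbers for stronger inhibition. Compound 1 stands at the lower of the two numbers, and compound 2 gives a higher number, a gap that lies beyond the usual scatter of this kind of measurement. Among the compounds with values here, the two compounds differ in more than one place, so their values show only that compound 1 is the stronger inhibitor of the pair, not what any single change does.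

The next compound, compound 3 `CN(c1ccc2[nH]c(-c3n[nH]c4ccccc34)cc2n1)S(=O)(=O)c1ccc(Cl)cc1`, keeps the shared core of compound 1 and changes one group: (4-chlorophenyl)sulfonyl in place of (4-chlorophenyl)carbonyl on a nitrogen on an aromatic ring. Within the data shown here, no measured pair shows the effect of this kind of exchange, so the expectation rests on compound 1 alone. The exchange replaces the group that carried the only acceptor on that nitrogen with one carrying two, and the account expects a moderate weakening rather than a gain, with the step of a 2.3-fold higher number from compound 1 to compound 3 (0.37 log units; beyond the scatter) estimated to lie just beyond the scatter. Compound 3 is therefore expected to give about 7000 nM in this assay, within a range from 1500 nM to 30000 nM.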

Compound 3, half-maximal inhibitory concentration: 5980 nM
Compound 3: the middle estimate sits 1.2-fold (0.07 log units) above what was measured; the range from low to high includes it.
By their numbers in this assay, from the lowest: compounds 1 and 3 (each within the scatter of the next); then compound 2.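

In this assay, the exchange of (4-chlorophenyl)carbonyl for (4-chlorophenyl)sulfonyl on a nitrogen on an aromatic ring gives a 2.0-fold higher number from compound 1 to compound 3 (0.30 log units; within the scatter), so this assay does not tell the two groups apart at this position. Within the data shown here, this is the first comparison here in which only one place differs, whereas the earlier pair, compound 1 and compound 2, could show no effect of any single change. Nothing given here explains why the two groups read alike.

The compounds shown leave open whether this result holds for other groups on the same nitrogen, such as a simple acetyl group, a longer alkyl chain or a sulfonyl group carrying an amine, and whether it would survive removal of the chlorine from the aromatic ring of that group. They also leave open what the nitrile of compound 2 contributes by itself, and whether replacing the methyl on that nitrogen with a longer chain would change the reading in this assay.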